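Bromine on the fused ring, tried on a second core

The source may hold more compounds than are shown below. What is called first, only, known or untested is meant among the compounds shown, and "the series" means these compounds.

Three compounds have been measured in a functional assay on cells (Cancer cell lines, Homo sapiens) for cytotoxicity, read by sulforhodamine B assay, with a stated time of 48 h; on this read-out lower numbers stand for stronger inhibition of growth and higher numbers for weaker inhibition of growth:

compound 1, `COc1ccc(C2CC(c3ccccc3)=NN2C2=NC(=O)/C(=C3\C(=O)Nc4ccccc43)S2)cc1`, gives 19000 nM
compound 2, `COc1ccc(C2CC(c3ccccc3)=NN2C2=NC(=O)/C(=C3\C(=O)Nc4ccc(Br)cc43)S2)cc1`, gives 3630 nM
compound 3, `COc1ccc(C2CC(c3ccc4ccccc4c3)=NN2C2=NC(=O)/C(=C3\C(=O)Nc4ccccc43)S2)cc1`, gives 24200 nM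

Compound 2 differs from compound 1 in one place: bromo in place of hydrogen on an aromatic carbon. This change brought a 5.2-fold lower number from compound 1 to compound 2 (0.72 log units; beyond the scatter), a step that stands clearly outside the usual scatter of this kind of measurement.

Compound 3 has a different core from compound 1; the difference is naphthalen-2-yl in place of phenyl on a carbon with a double bond to nitrogen. In this assay the result was a 1.3-fold higher number from compound 1 to compound 3 (0.11 log units; within the scatter), so the two cores cannot be told apart on the numbers measured here.

Compound 4, `COc1ccc(C2CC(c3ccc4ccccc4c3)=NN2C2=NC(=O)/C(=C3\C(=O)Nc4ccc(Br)cc43)S2)cc1`, has not yet been measured. It carries the same change relative to compound 3 that compound 2 carries relative to compound 1: bromo in place of hydrogen on an aromatic carbon. The surroundings of the change are described in the same words for both pairs, so it is the same change placed on a core that, as far as measured, behaves like the first one.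

On that basis the step from compound 3 to compound 4 is expected to resemble the earlier one, a 5.1-fold lower number from compound 3 to compound 4 (0.71 log units; beyond the scatter), because the same change gave a 5.2-fold lower number from compound 1 to compound 2 (0.72 log units; beyond the scatter). Compound 4 is therefore estimated at 4700 nM, with a range from 2000 nM to 12000 nM, resting on a single earlier example of the change.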

Compound 4, concentration for total growth inhibition: 850 nM
Beside the measured number, compound 4's estimate is 5.5-fold (0.74 log units) above it; the measured number lies below the stated range.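

In this assay the bromo change gave a 28-fold lower number from compound 3 to compound 4 (1.45 log units; beyond the scatter), so its direction carried over from one core to the other, but its size did not: the same change on two cores in this assay, a 5.2-fold lower number (0.72 log units; beyond the scatter) from compound 1 to compound 2 and a 28-fold lower number (1.45 log units; beyond the scatter) from compound 3 to compound 4, 5.4-fold (0.74 log units) apart, beyond the scatter of two such steps. The same four compounds can be read the other way round, with naphthalen-2-yl in place of phenyl making no readable difference without bromo but giving a 4.3-fold lower number from compound 2 to compound 4 (0.63 log units; beyond the scatter) with bromo present: the same change on two cores in this assay, a 1.3-fold higher number (0.11 log units; within the scatter) from compound 1 to compound 3 and a 4.3-fold lower number (0.63 log units; beyond the scatter) from compound 2 to compound 4, 5.4-fold (0.74 log units) apart, beyond the scatter of two such steps. In these four compounds the two changes therefore do not simply add up, and the earlier step was a guide to direction but not to size; this is a single case, and it does not show why the two groups act together or whether the same would happen on any other core.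

The compounds shown leave open whether the larger step belongs to bromo itself or would also appear with chloro, methyl or methoxy on the same aromatic carbon. They also leave open whether naphthalen-2-yl is needed for it, or whether another group on that carbon, such as a 4-chlorophenyl or a pyridine ring, would combine with bromo in the same way.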